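The compounds below may be only part of what the source reports. "The series", "measured", "known", "first", "only" and "open" are said of these compounds alone.

- compound 1 `COc1cc(NC(C)CCCNC(=O)NNC(=O)Nc2ccc(C(F)(F)F)cc2)c2ncccc2c1`: 12000 nM
- compound 2 `COc1cc(NC(C)CCCNC(=O)NNC(=O)Nc2cccc(C(F)(F)F)c2)c2ncccc2c1`: 21000 nM

In a functional assay on SW-620 cells (Homo sapiens) for inhibition, read by MTT assay, with a stated time of 72 h (on this read-out lower numbers stand for stronger inhibition and higher numbers for weaker inhibition), compound 2 gives 21000 nM, which cannot be separated from compound 1: the measured change is a 1.8-fold higher number from compound 1 to compound 2 (0.24 log units; within the scatter). Compound 3 `COc1cc(NC(C)CCCNC(=O)NNC(=O)Nc2cc(C(F)(F)F)cc(C(F)(F)F)c2)c2ncccc2c1` has one further alteration: trifluoromethyl in place of hydrogen on an aromatic carbon, with trifluoromethyl in place of hydrogen on an aromatic carbon. Among the compounds with values here, only that single measured step bears on it, and that step moved a trifluoromethyl group rather than adding one. The data therefore support no firm direction, and no change beyond the scatter is expected in this assay. The expected change is a 1.6-fold lower number from compound 2 to compound 3 (0.21 log units; within the scatter). For compound 3 the estimated value is 13000 nM, with an expected range of 4000 nM to 35000 nM.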

Compound 3, half-maximal inhibitory concentration: 16000 nM
Beside the measured number, compound 3's estimate is 1.2-fold (0.09 log units) below it, and the stated range covers the measured number.
By their numbers in this assay, from the lowest: compounds 1, 3 and 2 (each within the scatter of the next).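

In this assay a second trifluoromethyl, meta to a trifluoromethyl group on the aromatic ring, gives a 1.3-fold lower number from compound 2 to compound 3 (0.12 log units; within the scatter) and so no change that can be told from the scatter. The earlier step only moved a trifluoromethyl group, whereas this one shows that adding 4 heavy atoms at this position also leaves the number unresolved from that of compound 2. Nothing available gives a reason for this result. 

As far as these compounds go, whether a nitrile or an amine at this position would shift the number beyond the scatter stays open. So does the effect of a longer chain in the shared core.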